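Swapping Bromo for Fluoro on the Shared Core

This account rests on a few compounds, and the source may have more. Where it says the series, first, only, none or still open, it means among the compounds named here.

In a functional assay on Jurkat cells (Homo sapiens) for cytotoxicity, read by luminescence and CellTiter-Glo, with a stated time of 3 days (a higher number here means a weaker inhibitor, a lower number a stronger inhibitor), compound 3 (`O=C(Nc1ccc(C(F)(F)F)cc1)c1ccc(Br)cc1O`) gives 500 nM. Compound 2 (`O=C(Nc1ccc(C(F)(F)F)cc1)c1ccc(Cl)cc1O`) gives 670 nM, and compound 1 (`O=C(Nc1ccc(C(F)(F)F)cc1)c1cc(Br)c(F)cc1O`), which carries both a bromo and a fluoro group, gives 880 nM. Compound 3 therefore stands within the scatter of both other compounds, and this assay does not yet separate these three.

Compound 4 (`O=C(Nc1ccc(C(F)(F)F)cc1)c1ccc(F)cc1O`) is the next to be considered. It has fluoro in place of bromo on an aromatic carbon, meta to a hydroxy group and para to a large group: fluoro in place of bromo on an aromatic carbon.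

For the measured compounds named here, only one measured step bears directly on this change: the exchange of chloro for bromo at an aromatic carbon, a 1.3-fold lower number from compound 2 to compound 3 (0.13 log units; within the scatter). That step lies within the scatter, and no direct exchange of bromo for fluoro has been measured. The data therefore give little reason to expect a large move. With that small step as the guide, and allowing cautiously for a slight continuation of its trend, the expected change is a 1.6-fold higher number from compound 3 to compound 4 (0.20 log units; within the scatter), a shift toward a higher number that stays within the scatter. For compound 4, the estimated value is 800 nM, with an expected range of 350 nM to 2000 nM.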

Compound 4, half-maximal inhibitory concentration: 800 nM
Beside the measured number, compound 4's estimate shows no gap at the digits printed; the range from low to high includes it.
By their numbers in this assay, from the lowest: compounds 3, 2, 4 and 1 (each within the scatter of the next).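

At the aromatic carbon meta to a hydroxy group and para to a large group, three halogens can now be set side by side in this assay: fluoro in place of bromo gives a 1.6-fold higher number from compound 3 to compound 4 (0.20 log units; within the scatter), and fluoro in place of chloro gives a 1.2-fold higher number from compound 2 to compound 4 (0.08 log units; within the scatter), so this assay separates none of the three at this place. The second bromo-bearing compound adds a different kind of comparison, since taking away its bromo gives a 1.1-fold lower number from compound 1 to compound 4 (0.04 log units; within the scatter), and that extra bromo on the fluoro-bearing core is likewise not separated by this assay. Nothing is available that bears on why these numbers stay so close.

All the compounds shown carry a halogen at this place, so it remains open whether a plain hydrogen, an amine, a methoxy group or a carboxylic acid there would give a number outside the scatter. On these data alone, the hydroxy group and the trifluoromethyl group are also constant throughout, and what a methoxy group in place of that hydroxy, or a chloro in place of that trifluoromethyl, would do remains unknown.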